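Methyl on the Ring Carbon: Two Cores Compared

The compounds below may be only part of what the source reports. "The series", "measured", "known", "first", "only" and "open" are said of these compounds alone.

In a functional assay on the whole organism (strain Wistar Albino) for inhibition, with Rattus norvegicus as the target, read by paw edema, with a stated time of 1 h, at a dose of 20 mg/kg (on this read-out higher numbers stand for more inhibition at the one dose given (going by the name of the read-out) and lower numbers for less inhibition), compound 1 `Cc1cc(-c2nn3c(-c4ccoc4C)nnc3s2)c2ccccc2n1` gives 7.23%, compound 2 `Cc1occc1-c1nnc2sc(-c3ccnc4ccccc34)nn12` gives 12.5%, and compound 3 `COc1ccc(Cl)c(-c2nnc3sc(Cc4c[nH]c5ccc(OC)cc45)nn23)c1` gives 6.1%. The gaps between compound 3 and the other two lie within the scatter, so no order among the three can be claimed. The change methyl in place of hydrogen on an aromatic carbon gave, in this assay, a number 5.3 percentage points lower from compound 2 to compound 1 (within the scatter). The difference between the cores of compound 2 and compound 3 is not broken down here. Compound 4 `COc1ccc(Cl)c(-c2nnc3sc(Cc4c(C)[nH]c5ccc(OC)cc45)nn23)c1` is not yet measured; it differs from compound 3 by methyl in place of hydrogen on an aromatic carbon. Among the compounds with values here, this is the same kind of change as the one between compound 2 and compound 1, not the same one: there the methyl entered on an aromatic carbon of a six-membered aromatic ring with 1 nitrogen, meta to a fused ring, meta to a large group and para to a fused ring, while here it enters on an aromatic carbon of a five-membered aromatic ring with 1 nitrogen, next to the ring atom that bears a large group. Because the earlier step was a number 5.3 percentage points lower from compound 2 to compound 1 (within the scatter), the expected step in this assay is a number 1.1 percentage points lower from compound 3 to compound 4 (within the scatter), likewise within the scatter. For compound 4 in this assay the estimate is 5%, with a likely range from 0% to 14%.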

Compound 4, a percentage reported as inhibition, in the whole organism at one dose (the size of the read-out at that dose, not a potency): 11.3%
Compound 4: the middle estimate sits 6.3 percentage points below what was measured; low and high end bracket the measured number.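

In this assay, methyl in place of hydrogen on an aromatic carbon of the five-membered ring gave a number 5.2 percentage points higher from compound 3 to compound 4 (within the scatter). Set beside the earlier step on the other core, this one does not differ from it by more than two such steps would scatter: the same change on two cores in this assay, a number 5.3 percentage points lower (within the scatter) from compound 2 to compound 1 and a number 5.2 percentage points higher (within the scatter) from compound 3 to compound 4, 10.5 percentage points apart, within the scatter of two such steps The pair therefore shows only that, in this series, the change produced no step beyond the scatter on either core; it does not show that the effect of the methyl carries from one core to the other, nor that it differs between them.

The compounds shown leave open whether another group at this same place on the five-membered ring, such as an amine, a carboxylic acid or a longer chain, would give a step beyond the scatter. They also leave open how the methyl would read at one and the same place across cores, as the two steps sit on different rings.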